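The source may hold more compounds than are shown below. What is called first, only, known or untested is meant among the compounds shown, and "the series" means these compounds.

Measured compounds in a functional assay on CHO cells for antagonist activity at Orexin receptor type 2 (Homo sapiens), read by FLIPR and calcium flux; a higher number here means a weaker inhibitor, a lower number a stronger inhibitor:
- compound 1 `CCc1nc(C(F)(F)F)c2n1CCN([C@@H](C(=O)NC)c1ccccc1)[C@H]2CCc1ccc(C(F)(F)F)cc1` gives 11 nM
- compound 2 `CNC(=O)[C@@H](c1ccccc1)N1CCn2c(COC)nc(Cl)c2[C@@H]1CCc1ccc(C(F)(F)F)cc1` gives 25 nM
- compound 3 `CCc1nc(C(C)C)c2n1CCN([C@@H](C(=O)NC)c1ccccc1)C2CCc1ccc(C(F)(F)F)cc1` gives 2900 nM

Among these three, compound 2 holds the second highest number: compound 1 sits closest with a somewhat lower number, beyond the scatter, while compound 3 lies far away with a much higher number. Compound 4 `CNC(=O)[C@@H](c1ccccc1)N1CCn2c(C)nc(Cl)c2[C@@H]1CCc1ccc(C(F)(F)F)cc1` is not yet measured. It differs from compound 2 in one place, (hydrogen in place of methoxy on a saturated chain carbon bound to an aromatic carbon), that is, hydrogen in place of methoxy on a saturated chain carbon bound to an aromatic carbon. Within the data shown here, no measured pair shows this exact change, so the expected step in this assay is small, in either direction, likely within the scatter. Compound 4 is therefore estimated at 30 nM, with a range from 10 nM to 100 nM, a step of a 1.2-fold higher number from compound 2 to compound 4 (0.08 log units; within the scatter) that is expected to stay close to no change.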

Compound 4, half-maximal inhibitory concentration: 13 nM
Estimate against measurement, compound 4: 2.3-fold (0.36 log units) above; low and high end bracket the measured number.
By their numbers in this assay, from the lowest: compounds 1, 4 and 2 (each within the scatter of the next, the first and the last beyond it); then compound 3.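

In this assay, replacing methoxy with hydrogen on a saturated chain carbon bound to an aromatic carbon, which turns methoxymethyl into methyl, gives a 1.9-fold lower number from compound 2 to compound 4 (0.28 log units; within the scatter). This shows that the methoxy, with its 2 heavy atoms and 1 hydrogen-bond acceptor, can be removed from this position without a change beyond the scatter. Nothing measured here accounts for this result. The compounds shown leave open how this position would respond to a longer chain such as propyl, or to an amine. Whether a carboxylic acid or a hydroxyl group would also be accommodated there remains equally unknown.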